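The source may report more compounds than this note shows. Statements on the series, on what has been measured and on what is new or still open speak of the compounds shown alone.

Measured in a functional assay on MCF7 cells (Homo sapiens) for inhibition; on this read-out lower numbers stand for stronger inhibition and higher numbers for weaker inhibition:
compound 1, `CC/C(=C(/c1ccc(/C=C/C(=O)O)cc1)c1cc2ccccc2[nH]1)c1ccccc1`, gives 108 nM;
compound 2, `CC/C(=C(/c1ccc(/C=C/C(=O)O)cc1)c1cc2ccccc2[nH]1)c1ccccc1Cl`, gives 42 nM;
compound 3, `CC/C(=C(/c1ccc(/C=C/C(=O)O)cc1)c1cc2ccccc2[nH]1)c1ccc(C(F)(F)F)cc1`, gives 139 nM.

Compound 3 has the highest number of the three. Its gap to compound 1 is small: a 1.3-fold higher number from compound 1 to compound 3 (0.11 log units; within the scatter). Its gap to compound 2 is larger: a 3.3-fold higher number from compound 2 to compound 3 (0.52 log units; beyond the scatter). Compound 2 in turn stands apart from compound 1: a 2.6-fold lower number from compound 1 to compound 2 (0.41 log units; beyond the scatter).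

Compound 4, `CC/C(=C(/c1ccc(/C=C/C(=O)O)cc1)c1cc2ccccc2[nH]1)c1ccc(OC)cc1`, has not yet been measured in this assay. It differs from compound 3 by methoxy in place of trifluoromethyl on an aromatic carbon. Among the measured compounds shown here, none of the measured steps exchanges one substituent for another at this place, so the guidance is indirect. The closest comparison is the step of a 1.3-fold higher number from compound 1 to compound 3 (0.11 log units; within the scatter), which shows that putting trifluoromethyl at this place barely moved the number in this assay. The step of a 2.6-fold lower number from compound 1 to compound 2 (0.41 log units; beyond the scatter) concerns a different group at a different place on the ring and is only loosely related. A methoxy at the same place as the trifluoromethyl is expected to leave the number in the same region as that of compound 1 and compound 3. Compound 4 is therefore expected to show a step of a 1.4-fold lower number from compound 3 to compound 4 (0.14 log units; within the scatter) in this assay, within the scatter. Compound 4 is estimated to give 100 nM, with a range from 40 nM to 300 nM.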

Compound 4, half-maximal inhibitory concentration: 61 nM
For compound 4 the middle estimate is 1.6-fold (0.21 log units) above the measured one; low and high end bracket the measured number.
By their numbers in this assay, from the lowest: compounds 2, 4, 1 and 3 (each within the scatter of the next, the first and the last beyond it).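

In this assay, among the compounds shown here, this is the first exchange of one substituent for another on this aromatic carbon, and methoxy in place of trifluoromethyl gives a 2.3-fold lower number from compound 3 to compound 4 (0.36 log units; beyond the scatter) beyond the scatter, so the choice of group here can matter. Neither group stands clearly apart from hydrogen on its own: the steps of a 1.3-fold higher number from compound 1 to compound 3 (0.11 log units; within the scatter) and a 1.8-fold lower number from compound 1 to compound 4 (0.25 log units; within the scatter) both lie within the scatter, and only the direct comparison of the two substituted compounds separates them. The change of ring substitution read as a 1.5-fold higher number from compound 2 to compound 4 (0.16 log units; within the scatter) also lies within the scatter, so the 4-methoxyphenyl compound cannot be ranked against the 2-chlorophenyl compound, and this position now offers a second route into the range of the best number seen so far.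

The compounds shown leave open whether an amine, a hydroxyl or a longer alkoxy chain on this same aromatic carbon would follow methoxy or trifluoromethyl, and whether methoxy combined with the chloro group of compound 2 would add up. No measurement at hand accounts for the gap between methoxy and trifluoromethyl.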